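Nitrogen substituent on the ring amine of a benzimidazole acetamide series

The source may report more compounds than this note shows. Statements on the series, on what has been measured and on what is new or still open speak of the compounds shown alone.

Measured compounds:
compound 1 `CN1CCN(CC(=O)Nc2nc3ccccc3[nH]2)CC1` — 45%
compound 2 `O=C(CN1CCN(c2ccccn2)CC1)Nc1nc2ccccc2[nH]1` — 57.3%
compound 3 `COc1ccc(N2CCN(CC(=O)Nc3nc4ccccc4[nH]3)CC2)cc1` — 38.9%

In a functional assay, read by spectrophotometry, with a stated time of 30 min, tested at 100 ug/mL (a higher number here means a stronger effect of the compound at the concentration tested, a lower number a weaker effect), compound 1 gives 45%, the second highest of the three numbers. Compound 2 stands a number 12.3 percentage points higher from compound 1 to compound 2 (beyond the scatter), a step beyond the scatter; compound 3 sits a number 6.1 percentage points lower from compound 1 to compound 3 (within the scatter), within the scatter, so compound 1 and compound 3 cannot be ordered. Between the two aryl-bearing compounds the change runs a number 18.4 percentage points lower from compound 2 to compound 3 (beyond the scatter).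

Compound 4 `O=C(CN1CCN(c2ccc([N+](=O)[O-])cc2)CC1)Nc1nc2ccccc2[nH]1` is not yet measured. From compound 1 the change is 4-nitrophenyl in place of methyl on an amine nitrogen in a ring. Among the compounds with values here, the steps that bear on it are those that also replace the methyl on the ring amine: the 4-methoxyphenyl case, within the scatter, and the pyridin-2-yl case, modestly higher. The 4-nitrophenyl group is a six-membered carbon-only aromatic ring like 4-methoxyphenyl rather than a pyridin-2-yl, so the 1>3 step is the closer precedent. No step beyond the scatter is therefore expected for a number 2 percentage points lower from compound 1 to compound 4 (within the scatter), and compound 4 is estimated at 43%, with a range from 29% to 57% in this assay.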

Compound 4, a percentage reported as activity, at one concentration (the size of the read-out at that concentration, not a potency): 51.7%
Estimate against measurement, compound 4: 8.7 percentage points below; low and high end bracket the measured number.
By their numbers in this assay, from the lowest: compounds 3, 1, 4 and 2 (each within the scatter of the next, the first and the last beyond it).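

Within the data shown here, with the 4-methoxyphenyl group on the amine nitrogen in the ring as the reference, this assay gives the first look at a change on the aromatic ring itself, nitro in place of methoxy on an aromatic carbon, and the step of a number 12.8 percentage points higher from compound 3 to compound 4 (beyond the scatter) shows that this aromatic substituent can move the read-out beyond the scatter. The 4-nitrophenyl group cannot be ordered against either methyl, with a number 6.7 percentage points higher from compound 1 to compound 4 (within the scatter) in the first comparison, or pyridin-2-yl, with a number 5.6 percentage points lower from compound 2 to compound 4 (within the scatter) in the second. No measurement at hand explains the difference between nitro and methoxy.

On these data alone, whether this difference extends to other groups on that aromatic carbon, such as a nitrile, an amine or a carboxylic acid, stays open. The compounds shown also leave open how a benzyl group on the same ring nitrogen would compare.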